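A ring methyl added to compound 1: what to expect

This account rests on a few compounds, and the source may have more. Where it says the series, first, only, none or still open, it means among the compounds named here.

Compound 1 `CCCCCn1c(N)nc2ccccc21`: 3230 nM
Compound 2 `CCCCCCn1c(N)nc2ccccc21`: 3960 nM
Compound 3 `CCCCCn1c(N)nc2ccncc21`: "not active" (no number reported)

In an assay on HEK293 cells for agonist activity at Toll-like receptor 8 (Homo sapiens), read by reporter gene assay (a lower number here means that less compound is needed, a higher number that more compound is needed for the effect), compound 1 gives 3230 nM, the lowest of the two numbers measured. Compound 2 gives 3960 nM; the step of a 1.2-fold higher number from compound 1 to compound 2 (0.09 log units; within the scatter) changes only the chain. Compound 3 was reported as "not active" (no number reported) without a number. Compound 4 `CCCCCn1c(N)nc2c(C)cccc21` differs from compound 1 by methyl in place of hydrogen on an aromatic carbon. Going by the values given here, no measured step concerns a substituent on an aromatic carbon, so nothing here tells how large this change should be; the one measured step lies within the scatter. Compound 4 is therefore expected to give about 3000 nM, somewhere between 1000 nM and 10000 nM. That expectation means a step of a 1.1-fold lower number from compound 1 to compound 4 (0.03 log units; within the scatter), not beyond the scatter.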

Compound 4, half-maximal effective concentration: 1130 nM
Compound 4: middle estimate off by 2.7-fold (0.42 log units), on the high side; measured number inside the range.
By their numbers in this assay, from the lowest: compound 4; then compounds 1 and 2 (each within the scatter of the next).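

In this assay, methyl in place of hydrogen on an aromatic carbon, ortho to a fused ring and meta to a fused ring, gives a 2.9-fold lower number from compound 1 to compound 4 (0.46 log units; beyond the scatter), a step beyond the scatter. Going by these compounds alone, the one earlier step, on the chain, stayed within the scatter, so this ring place responds to a single added methyl in a way the chain change did not. As far as these compounds go, whether ethyl, methoxy or an amine on this carbon would lower the number further stays open, as does the effect of methyl on the other aromatic carbons. Nothing measured here speaks to the reason for this step.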